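Naphthyl replacement at the saturated ring carbon

The compounds below may be only part of what the source reports. "The series", "measured", "known", "first", "only" and "open" are said of these compounds alone.

Compound 1 `Cc1ccc(C2C(C#N)=C(N)N(c3ccc(S(N)(=O)=O)cc3)C3=C2C(=O)CCC3)cc1` holds the highest of the two numbers in hand: in a functional assay on Ehrlich cells (Mus musculus) for antiproliferative activity, read by trypan blue exclusion, with a stated time of 2 h (on this read-out higher numbers stand for weaker inhibition and lower numbers for stronger inhibition), compound 1 gives 50 ug/mL. Its nearest neighbour is compound 2 `COc1ccc(C2C(C#N)=C(N)N(c3ccc(S(N)(=O)=O)cc3)C3=C2C(=O)CCC3)cc1`, which in this assay gives 25 ug/mL; the step of a 2.0-fold lower number from compound 1 to compound 2 (0.30 log units; within the scatter) stays within the scatter. Compound 3 `COc1ccc2ccccc2c1C1C(C#N)=C(N)N(c2ccc(S(N)(=O)=O)cc2)C2=C1C(=O)CCC2` is not yet measured. It differs from compound 1 as follows: 2-methoxynaphthalen-1-yl in place of 4-methylphenyl on a saturated ring carbon. Among the measured compounds shown here, the only measured step that touches this change is a 2.0-fold lower number from compound 1 to compound 2 (0.30 log units; within the scatter), which also brings methoxy in place of methyl on an aromatic carbon but keeps a single ring; nothing in hand covers a second aromatic ring. On this basis no step beyond the scatter is expected, with at most a somewhat lower number in this assay. The step is therefore estimated at a 1.4-fold lower number from compound 1 to compound 3 (0.15 log units; within the scatter). Compound 3 is expected to give about 35 ug/mL in this assay, within a range of 12 ug/mL to 100 ug/mL.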

Compound 3, half-maximal inhibitory concentration: 12.5 ug/mL
The estimate for compound 3 lay 2.8-fold (0.45 log units) above the measured number, and the stated range covers the measured number.
By their numbers in this assay, from the lowest: compounds 3, 2 and 1 (each within the scatter of the next, the first and the last beyond it).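

In this assay, among the compounds shown here, 2-methoxynaphthalen-1-yl in place of 4-methylphenyl on the saturated ring carbon gives the first step beyond the scatter (a 4.0-fold lower number from compound 1 to compound 3 (0.60 log units; beyond the scatter)), so this position tolerates a group with 2 six-membered aromatic rings. Against 4-methoxyphenyl, the same group gives a step that stays within the scatter (a 2.0-fold lower number from compound 2 to compound 3 (0.30 log units; within the scatter)), so the separation holds against compound 1 only and compound 3 is not set apart from compound 2. Nothing measured on hand accounts for either step.

On these data alone, compound 3 brings the second aromatic ring and the methoxy together, and which of them carries the step remains open. Also open, as far as these compounds go, is how this position responds to a non-aromatic group such as cyclohexyl, or to an aryl group bearing an amine or a carboxylic acid.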